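Series notes: amide substituent on the benzylic methylene

The source may hold more compounds than are shown below. What is called first, only, known or untested is meant among the compounds shown, and "the series" means these compounds.

For the measured compounds named here, compound 2 `CN[C@H](C)C(=O)NCc1cccc(Cn2nc(NS(=O)(=O)c3ccc(Cl)s3)c3c(OC)cccc32)c1` stands as the lower of the two numbers so far: in an assay on isolated protein (blood) for antagonist activity at C-C chemokine receptor type 4 (Homo sapiens), read by flow cytometry, with a stated time of 30 min (a lower number here means tighter binding, a higher number weaker binding), compound 2 gives 200 nM, while compound 1 `COc1cccc2c1c(NS(=O)(=O)c1ccc(Cl)s1)nn2Cc1cccc(CNC(=O)C2CCCO2)c1` gives 794 nM, the step of a 4.0-fold lower number from compound 1 to compound 2 (0.60 log units; beyond the scatter). Compound 3 `COc1cccc2c1c(NS(=O)(=O)c1ccc(Cl)s1)nn2Cc1cccc(CNC(=O)C(C)(C)N)c1` carries the change (1-amino-1-methylethyl in place of 1-(methylamino)ethyl on a carbonyl carbon). Going by the values given here, no measured step rearranges the same atoms in this way; the single step known, from an oxolanyl to an open-chain amine, does not bear on it directly. No step beyond the scatter is therefore expected, with the estimated step of a 1.3-fold higher number from compound 2 to compound 3 (0.10 log units; within the scatter). Compound 3 is estimated at 250 nM, range 100 nM to 630 nM.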

Compound 3, dissociation constant: 141 nM
Estimate against measurement, compound 3: 1.8-fold (0.25 log units) above, and the stated range covers the measured number.
By their numbers in this assay, from the lowest: compounds 3 and 2 (each within the scatter of the next); then compound 1.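

In this assay the swap of 1-(methylamino)ethyl for 1-amino-1-methylethyl on a carbonyl carbon, the same atoms joined differently and the defined stereocentre gone, gives a 1.4-fold lower number from compound 2 to compound 3 (0.15 log units; within the scatter) and so this position accepts the rearrangement. The change from oxolan-2-yl to 1-amino-1-methylethyl gives a 5.6-fold lower number from compound 1 to compound 3 (0.75 log units; beyond the scatter) and so confirms, with a second open-chain amine, a gap beyond the scatter from the oxolan-2-yl amide. Nothing measured here explains either step.

From the compounds shown here alone, whether the amine nitrogen itself is needed stays open. A carboxylic acid or a plain isopropyl group on the same carbonyl carbon would test that.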